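Dichlorophenyl in Place of Phenyl on a Sulfonamide Core

The source may hold more compounds than are shown below. What is called first, only, known or untested is meant among the compounds shown, and "the series" means these compounds.

Three compounds have been measured in a functional assay on Ehrlich cells (Mus musculus) for antiproliferative activity, read by trypan blue exclusion, with a stated time of 2 h, tested at 10 ug/mL; on this read-out higher numbers stand for a stronger effect at the one concentration tested and lower numbers for a weaker effect:
compound 1 `N#CC1=C(N)N(c2ccc(S(N)(=O)=O)cc2)C2=C(C(=O)CCC2)C1c1ccccc1` — 10%
compound 2 `COc1ccccc1C1C(C#N)=C(N)N(c2ccc(S(N)(=O)=O)cc2)C2=C1C(=O)CCC2` — 0%
compound 3 `COc1cc(CC2C(C#N)=C(N)N(c3ccc(S(N)(=O)=O)cc3)C3=C2C(=O)CCC3)ccc1O` — 0%

Compound 1 shows the highest of the three numbers, but its lead is thin: the step of a number 10 percentage points lower from compound 1 to compound 2 (within the scatter) and the step of a number 10 percentage points lower from compound 1 to compound 3 (within the scatter) both lie within the scatter, as does the step of no change at the digits printed from compound 2 to compound 3 (within the scatter). Among the compounds with values here, on these numbers no compound can be called more active than another; all three sit near the bottom of the read-out.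

Compound 4 `N#CC1=C(N)N(c2ccc(S(N)(=O)=O)cc2)C2=C(C(=O)CCC2)C1c1ccc(Cl)cc1Cl` has not yet been measured. Compared with compound 1, the change is 2,4-dichlorophenyl in place of phenyl on a saturated ring carbon. The two measured steps that bear on it are the substitution of a methoxy on an aromatic carbon from compound 1 to compound 2 and the exchange of the phenyl for a 4-hydroxy-3-methoxybenzyl from compound 1 to compound 3. Neither moved the read-out beyond the scatter, and both changes concern the same phenyl group that is exchanged here. The expectation is therefore a step of a number 3 percentage points lower from compound 1 to compound 4 (within the scatter) that stays within the scatter. Compound 4 is estimated at 7%, with a range from 0% to 22%.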

Compound 4, a percentage reported as activity, at one concentration (the size of the read-out at that concentration, not a potency): 40%
Beside the measured number, compound 4's estimate is 33 percentage points below it, and the stated range ends below it.
By their numbers in this assay, from the lowest: compounds 2, 3 and 1 (each within the scatter of the next); then compound 4.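

In this assay, within the data shown here, this saturated ring carbon proves able to change the read-out: 2,4-dichlorophenyl in place of phenyl brings a number 30 percentage points higher from compound 1 to compound 4 (beyond the scatter) and gives the first step in this set that clears the usual scatter. The same group also stands well apart from the two oxygen-bearing groups at this position, with a number 40 percentage points higher from compound 2 to compound 4 (beyond the scatter) against 2-methoxyphenyl and a number 40 percentage points higher from compound 3 to compound 4 (beyond the scatter) against 4-hydroxy-3-methoxybenzyl, so the flat picture left by compounds 1, 2 and 3 does not hold for every group placed here. No independent information at hand accounts for this rise.

What the compounds shown leave open is whether both chlorines are needed, since a phenyl with a single chlorine, or with bromine or methyl in place of the chlorines, would separate the contribution of each. Also open, on these data alone, is how the read-out responds to an amine or a carboxylic acid on this phenyl, and whether the effect of compound 4 grows with concentration, since a single concentration gives the size of the effect and not a potency.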